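Chain-end ester on the urea series

The source may report more compounds than this note shows. Statements on the series, on what has been measured and on what is new or still open speak of the compounds shown alone.

Measured so far:
compound 1 `CCCCCCN1NN=C(NC(=O)Nc2c(C(C)C)cccc2C(C)C)N1`: 73 nM
compound 2 `CCCCCCCCCCCN1NN=C(NC(=O)Nc2c(C(C)C)cccc2C(C)C)N1`: 9 nM
compound 3 `CCCCCCCCCCCCN1NN=C(NC(=O)Nc2c(C(C)C)cccc2C(C)C)N1`: 14 nM

In an assay on microsomes from intestine for inhibition of acyl-CoA:cholesterol acyltransferase (Oryctolagus cuniculus) (a lower number here means a stronger inhibitor, a higher number a weaker inhibitor), compound 3 gives 14 nM, the second highest of the three numbers. The step of a 1.6-fold higher number from compound 2 to compound 3 (0.19 log units; within the scatter) lies within the scatter, so compound 2 and compound 3 cannot be ordered; the step of a 5.2-fold lower number from compound 1 to compound 3 (0.72 log units; beyond the scatter) lies beyond it, as does an 8.1-fold lower number from compound 1 to compound 2 (0.91 log units; beyond the scatter). Both steps beyond the scatter are chain lengthenings from the shortest chain.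

Compound 4 `COC(=O)CCCCCCCCCCN1NN=C(NC(=O)Nc2c(C(C)C)cccc2C(C)C)N1` differs from compound 3 by methoxycarbonyl in place of ethyl on a saturated chain carbon, ten or more bonds along the chain from an amine nitrogen in a ring. For the measured compounds named here, no measured step swaps a chain-end carbon for an ester; the three steps change only chain length and bear on this change indirectly. They show that, once the chain is long, a small change at its far end read as within the scatter, but they give no reading for two oxygen acceptors at that position. The change is therefore expected to give a modest rise in the number, of uncertain size.

Compound 4 is expected to give 30 nM, with a range of 8 nM to 110 nM.

This estimate means a 2.1-fold higher number from compound 3 to compound 4 (0.33 log units; beyond the scatter), a step expected to sit near the edge of the scatter.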

Compound 4, half-maximal inhibitory concentration: 4700 nM
Compound 4: the middle estimate sits 160-fold (2.19 log units) below what was measured; the measured number lies above the stated range.
By their numbers in this assay, from the lowest: compounds 2 and 3 (each within the scatter of the next); then compound 1; then compound 4.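

In this assay the far end of the long chain, where one methyl more read as within the scatter, turns out to be highly sensitive to methoxycarbonyl in place of ethyl, with a 340-fold higher number from compound 3 to compound 4 (2.53 log units; beyond the scatter) and a 520-fold higher number from compound 2 to compound 4 (2.72 log units; beyond the scatter) for the same chain end. The gain from lengthening the chain does not survive this change, since a 64-fold higher number from compound 1 to compound 4 (1.81 log units; beyond the scatter) puts the ester-ended chain behind even the shortest chain of the series. Nothing shown here gives a reason for this loss.

On these data alone, whether the loss belongs to the methoxycarbonyl itself or to oxygen at the chain end in general stays open, and a carboxylic acid, a primary alcohol or an ether at the same place would separate the two. Also open, as far as these compounds go, is whether a shorter chain ending in the same ester, such as 3-(methoxycarbonyl)propyl, would lose as much.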